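Cyanophenyl placement on a dihydropyridine core and guinea pig muscle response

A few compounds are considered here, and "the series" means these few. Any claim that something is new, unique, unknown or untested is made for them only; others in the source may bear on it.

Compound 1 `COC(=O)C1=C(C)N=C(C)/C(=C(\O)OC)C1c1cccc(OC(=O)c2ccccc2)c1` in a functional assay (muscle tissue) with Cavia porcellus as the target (a higher number here means that more compound is needed for the effect, a lower number that less compound is needed), gives 6310 nM.
Compound 2 `COC(=O)C1=C(C)N=C(C)/C(=C(\O)OC)C1c1ccccc1C#N` in this assay gives 15.9 nM.
Compound 3 `COC(=O)C1=C(C)N=C(C)/C(=C(\O)OC)C1c1cc([N+](=O)[O-])ccc1Cl` in this assay gives 30.2 nM.

Among the three measured compounds, compound 2 has the lowest number in this assay; its gap to compound 3 lies within the scatter, while compound 1 sits far beyond it. Compound 4 `COC(=O)C1=C(C)N=C(C)/C(=C(\O)OC)C1c1ccc(C#N)cc1` has not yet been measured. It differs from compound 2 in one respect: 4-cyanophenyl in place of 2-cyanophenyl on a saturated ring carbon. Among the compounds with values here, no measured pair here separates these two placements of the nitrile group, so the size of the step is open. Within the data shown here, compound 1, the one measured compound whose group is not on the ring carbon bearing the aromatic substituent in the same way, shows a much higher number. Compound 4 is expected to need more compound than compound 2, with a step of a 94-fold higher number from compound 2 to compound 4 (1.97 log units; beyond the scatter). The estimated value for compound 4 is 1500 nM, in a range from 250 nM to 9000 nM.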

Compound 4, half-maximal effective concentration: 3470 nM
Estimate against measurement, compound 4: 2.3-fold (0.36 log units) below, within the range that was stated.
By their numbers in this assay, from the lowest: compounds 2 and 3 (each within the scatter of the next); then compounds 4 and 1 (each within the scatter of the next).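

On the saturated ring carbon of the shared core, 4-cyanophenyl in place of 2-cyanophenyl gives a 220-fold higher number from compound 2 to compound 4 (2.34 log units; beyond the scatter) in this assay. Both groups have the same heavy atoms and the same hydrogen-bond acceptor count, so where the nitrile sits on the phenyl ring alone makes a large difference to the number. No measurement available here accounts for the size of this step.

On these data alone, whether an amine or a carboxylic acid in place of the nitrile would show a similar dependence on placement stays open.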